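This account rests on a few compounds, and the source may have more. Where it says the series, first, only, none or still open, it means among the compounds named here.

Compound 2 `COc1ccc(C(=O)OC2CCC(CN3CCN(c4cc(=O)c5cc(C(F)(F)F)cc([N+](=O)[O-])c5s4)CC3)CC2)cc1` gives 0.165 h in an ADME assay on cells (Hepatocyte, Homo sapiens) for metabolic stability; a higher number here means that the compound lasts longer, a lower number that the compound disappears faster. Of the two plain numbers shown it is the higher, and the nearest is compound 3 `O=C(OC1CCC(CN2CCN(c3cc(=O)c4cc(C(F)(F)F)cc([N+](=O)[O-])c4s3)CC2)CC1)c1ccc(C(F)(F)F)cc1`, which gives 0.117 h; the step of a 1.4-fold lower number from compound 2 to compound 3 (0.15 log units; within the scatter) is within the scatter, so the two cannot be told apart. Compound 1 `CC(=O)NC1CCC(CN2CCN(c3cc(=O)c4cc(C(F)(F)F)cc([N+](=O)[O-])c4s3)CC2)CC1` gives > 1.55 h, and that is a limit of the assay rather than a number (the limit of > 1.55 h in this assay, at which 1 of the 3 values shown sits). The step of an at least 9.3-fold lower number from compound 1 to compound 2 (0.97 log units; beyond the scatter) is the one large step shown, and it arose from swapping the group on the saturated ring carbon.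

Compound 4 `O=c1cc(N2CCN(CC3CCC(NS(=O)(=O)c4ccccc4)CC3)CC2)sc2c([N+](=O)[O-])cc(C(F)(F)F)cc12` carries (phenylsulfonyl)amino in place of ((4-methoxyphenyl)carbonyl)oxy on a saturated ring carbon. The change sits at the same saturated ring carbon that was altered in the step from compound 1 to compound 2, and that step was large, while the step from compound 2 to compound 3, which only touched the aromatic carbon, stayed within the scatter. A sizeable step in this assay is therefore expected, upward, as a 3.6-fold higher number from compound 2 to compound 4 (0.56 log units; beyond the scatter). Compound 4 is estimated at 0.6 h, between 0.25 h and 1.5 h.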

Compound 4, half-life: > 1.55 h
Compound 4: only a limit was reported; the forecaster's own chance of this, stated with the estimate: 15%; middle value at least 2.5-fold (0.41 log units) from the limit.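

In this assay, putting (phenylsulfonyl)amino in place of ((4-methoxyphenyl)carbonyl)oxy on the saturated ring carbon gives an at least 9.3-fold higher number from compound 2 to compound 4 (0.97 log units; beyond the scatter). Two different groups attached through nitrogen at this carbon, acetamido in compound 1 and (phenylsulfonyl)amino in compound 4, now each give a large step from compound 2, so the earlier large step is not unique to acetamido. Compound 4 gives > 1.55 h, which is a limit of the assay and not a number: the limit of > 1.55 h in this assay, at which 2 of the 4 values shown sit.

On these data alone, the step from compound 1 to compound 4 cannot be read, so the order of acetyl and phenylsulfonyl on the amine nitrogen remains unknown. Also open, as far as these compounds go, is what acetyloxy or a plain amine on this ring carbon would give, which would help separate the effect of the linking atom from that of the rest of the group.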